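Cyclohexyl to heptyloxy: working notes on compound 3

A few compounds are considered here, and "the series" means these few. Any claim that something is new, unique, unknown or untested is made for them only; others in the source may bear on it.

Measured in a functional assay on brain (Rattus norvegicus, strain Wistar) for inhibition; on this read-out lower numbers stand for stronger inhibition and higher numbers for weaker inhibition
- Compound 1 `Cc1[nH]c(=O)n(C2CCCCC2)c1-c1ccccc1` gives 47600 nM
- Compound 2 `Cc1[nH]c(=O)n(C2CCCCC2)c1-c1ccc(C2CCCCC2)cc1` gives 28900 nM

Compound 2 stands within the scatter of compound 1, so these two values set no order. Within the data shown here, the only measured step is a 1.6-fold lower number from compound 1 to compound 2 (0.22 log units; within the scatter), with cyclohexyl in place of hydrogen on an aromatic carbon. The next structure is compound 3 `CCCCCCCOc1ccc(-c2c(C)[nH]c(=O)n2C2CCCCC2)cc1`, and the change is heptyloxy in place of cyclohexyl on an aromatic carbon. Heptyloxy takes the place of cyclohexyl on an aromatic carbon, para to a large group.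

Among the measured compounds shown here, the measured step bears on this change only in part, since it concerns the same place on the ring but no measured compound carries heptyloxy. For the measured compounds named here, with compound 2 at 28900 nM and only that small step as a guide, no shift beyond the scatter is expected in this assay, with a slight lean towards a lower number. The expected step is a 1.3-fold lower number from compound 2 to compound 3 (0.12 log units; within the scatter). For compound 3 the estimate is 22000 nM, with an expected range of 6000 nM to 60000 nM.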

Compound 3, half-maximal inhibitory concentration: 11600 nM
Compound 3: middle estimate off by 1.9-fold (0.28 log units), on the high side; measured number inside the range.
By their numbers in this assay, from the lowest: compound 3; then compounds 2 and 1 (each within the scatter of the next).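

In this assay, this place on the aromatic ring, para to a large group, now gives steps beyond the scatter: a 2.5-fold lower number from compound 2 to compound 3 (0.40 log units; beyond the scatter) and a 4.1-fold lower number from compound 1 to compound 3 (0.61 log units; beyond the scatter), both modest. Cyclohexyl in place of hydrogen gave only a 1.6-fold lower number from compound 1 to compound 2 (0.22 log units; within the scatter), which lies within the scatter, so the earlier compounds did not show that a change at this place can move the number, and heptyloxy, with no ring and one hydrogen-bond acceptor, is the first group here to do so. Nothing available explains why heptyloxy and cyclohexyl differ at this place.

Heptyloxy differs from cyclohexyl in several ways at once, so the compounds shown do not separate the contribution of the open chain from that of its oxygen; a plain heptyl chain and a shorter methoxy group would bear on these two points. Also open, on these data alone, is how an amine or a carboxylic acid at this same place would compare in this read-out, and whether a longer chain than heptyloxy would lower the number further in this assay.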